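Benzyl in place of butyl on the aminopyrimidine nitrogen

This account rests on a few compounds, and the source may have more. Where it says the series, first, only, none or still open, it means among the compounds named here.

Compound 3 `CCCCNc1ncc(-c2cccc(Cl)c2)c(-c2ccccc2)n1` gives 56% in an assay on CHO cells for displacement of a labelled ligand from adenosine receptor A1 (Homo sapiens), read by scintillation counting, with a stated time of 1 h, tested at 1 uM (on this read-out lower numbers stand for less inhibition and higher numbers for more inhibition at the one concentration tested (going by the name of the read-out)), the lowest of the two numbers shown. Compound 2 `CNc1ncc(-c2cccc(Cl)c2)c(-c2ccccc2)n1` gives 75% in this assay. Compound 1 `Clc1cccc(-c2cnc(NC3CCCC3)nc2-c2ccccc2)c1` reaches only a limit of this assay, > 80%, so its number is not known; the limit of > 80% in this assay, at which 1 of the 3 values shown sits, marks that boundary.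

Compound 4 `Clc1cccc(-c2cnc(NCc3ccccc3)nc2-c2ccccc2)c1` differs from compound 3 by phenyl in place of propyl on a saturated chain carbon bound to a nitrogen on an aromatic ring. Among the measured compounds shown here, no measured step exchanges exactly these groups, but three steps touch the same position. The change a number 19 percentage points lower from compound 2 to compound 3 (beyond the scatter) shows that lengthening the chain lowered the read-out. The change a number at least 24 percentage points lower from compound 1 to compound 3 (beyond the scatter) shows that a ring on the nitrogen stood well above the open butyl chain, while a number at least 5 percentage points lower from compound 1 to compound 2 (that floor lies within the scatter) stayed within the scatter. The ring of compound 1 sat directly on the nitrogen; in compound 4 the ring sits on a saturated chain carbon, so these steps guide only loosely.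

Compound 4 is therefore expected to recover part of the ground lost by compound 3, an estimated upward step of a number 14 percentage points higher from compound 3 to compound 4 (beyond the scatter) in this assay. The estimate for compound 4 is 70%, within a range from 50% to 88%.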

Compound 4, a percentage reported as inhibition, at one concentration (the size of the read-out at that concentration, not a potency): 16%
For compound 4 the middle estimate is 54 percentage points above the measured one, outside the stated range (below it).
By their numbers in this assay, from the lowest: compound 4; then compound 3; then compound 2. At a limit, above all of these: compound 1.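

In this assay both a number 40 percentage points lower from compound 3 to compound 4 (beyond the scatter) and a number 59 percentage points lower from compound 2 to compound 4 (beyond the scatter) put the benzyl compound lowest of those with a number, so the fall seen from methyl to butyl went on and a phenyl on the saturated chain carbon bound to the nitrogen did not reverse it. A ring on this nitrogen therefore does not by itself keep the read-out high, as a number at least 64 percentage points lower from compound 1 to compound 4 (beyond the scatter) shows against cyclopentyl, and compound 1 goes against any simple trend of falling numbers with larger groups, with its ring directly on the nitrogen whereas the ring of compound 4 sits on a saturated chain carbon. Compound 1 stands at a limit, so that step can be read only as a floor: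

the limit of > 80% in this assay, at which 1 of the 4 values shown sits.

The compounds shown leave open whether the saturated chain carbon that carries the ring is what separates these results, a question that cyclohexyl or phenyl directly on the nitrogen would speak to. They also leave open how a longer chain such as phenethyl, or a benzyl ring carrying a hydroxyl or an amine, would read in this assay at this position.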